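The source may report more compounds than this note shows. Statements on the series, on what has been measured and on what is new or still open speak of the compounds shown alone.

In a functional assay on HCT-15 cells (Homo sapiens) for inhibition, with a stated time of 48 h (on this read-out higher numbers stand for weaker inhibition of growth and lower numbers for stronger inhibition of growth), compound 1 `COc1ccccc1/C=C/C(=O)c1c(O)cc2occc2c1OC` reports only a limit, > 100000 nM. Compound 2 `COc1c(C(=O)/C=C/c2ccc(Cl)cc2)c(O)c(Br)c2occc12` gives 3430 nM and compound 3 `C=CCc1c(O)c(C(=O)/C=C/c2ccccc2)c(OC)c2ccoc12` gives 2910 nM, two numbers within the scatter of each other. Compound 4 `C=CCc1c(O)c(C(=O)/C=C/c2ccc(Cl)cc2)c(OC)c2ccoc12` differs from compound 3 by chloro in place of hydrogen on an aromatic carbon, para to a large group, which turns phenyl into 4-chlorophenyl (chloro in place of hydrogen on an aromatic carbon). Within the data shown here, no measured pair isolates this change in this assay. Compound 2 also carries 4-chlorophenyl and gives 3430 nM, so no step beyond the scatter is expected, in either direction. The estimated step is a 1.0-fold lower number from compound 3 to compound 4 (0.02 log units; within the scatter). For compound 4 the expected value is 2800 nM, with an estimated range from 1000 nM to 7000 nM.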

Compound 4, concentration for 50% growth inhibition: 3400 nM
Beside the measured number, compound 4's estimate is 1.2-fold (0.08 log units) below it; the measured number falls inside the stated range.
By their numbers in this assay, from the lowest: compounds 3, 4 and 2 (each within the scatter of the next). At a limit, above all of these: compound 1.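

Among these compounds, the pair printed as a 1.2-fold higher number from compound 3 to compound 4 (0.07 log units; within the scatter) in this assay is the first direct reading of this change: 4-chlorophenyl in place of phenyl stays within the scatter. The pair printed as a 1.0-fold lower number from compound 2 to compound 4 (0.00 log units; within the scatter) adds a second reading, in which allyl in place of bromo on an aromatic carbon, with 4-chlorophenyl present in both compounds, also stays within the scatter. Nothing available here bears on a reason for either result. From the compounds shown here alone, whether an amine or a carboxylic acid in place of chloro on that ring would shift the number remains open. So does whether the chloro step would read the same with bromo in place of allyl.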